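The compounds below may be only part of what the source reports. "The series", "measured", "known", "first", "only" and "open" are said of these compounds alone.

Compound 1, `CC1=C(C(=O)Nc2ccc([N+](=O)[O-])cc2)C(c2ccc(Br)cc2)N=C(SCc2ccc(Cl)cc2)N1`, is the starting point. In a functional assay on the whole organism (artery, strain albino) with Rattus norvegicus as the target, with a stated time of 900 min, at a dose of 10 mg/kg by the oral route (a lower number here means less inhibition, a higher number more inhibition at the dose given (going by the name of the read-out)), compound 1 gives 19%. Compound 2, `CC1=C(C(=O)Nc2ccc([N+](=O)[O-])cc2)C(c2ccc(Br)cc2)N=C(SCc2ccc(F)cc2)N1`, differs from it in one place: fluoro in place of chloro on an aromatic carbon. In this assay compound 2 gives 22.6%, so the step is a number 3.6 percentage points higher from compound 1 to compound 2 (within the scatter). Compound 3, `CC1=C(C(=O)Nc2ccc([N+](=O)[O-])cc2)C(c2cccc([N+](=O)[O-])c2)N=C(SCc2ccc(Cl)cc2)N1`, carries a different core, and the counted difference is 3-nitrophenyl in place of 4-bromophenyl on a saturated ring carbon. In this assay compound 3 gives 12.3%, which makes the step of a number 6.7 percentage points lower from compound 1 to compound 3 (within the scatter). Compound 4, `CC1=C(C(=O)Nc2ccc([N+](=O)[O-])cc2)C(c2cccc([N+](=O)[O-])c2)N=C(SCc2ccc(F)cc2)N1`, has not been measured yet and stands to compound 3 as compound 2 stands to compound 1: fluoro in place of chloro on an aromatic carbon. The surroundings of the change read the same in both pairs, so it is the same change, made on the core of compound 3 rather than on the core of compound 1. For the measured compounds named here, only one earlier instance of this change exists, and it was small. The step from compound 3 to compound 4 in this assay is therefore expected to be a number 3.7 percentage points higher from compound 3 to compound 4 (within the scatter), resting on the step of a number 3.6 percentage points higher from compound 1 to compound 2 (within the scatter). For compound 4 the estimate in this assay is 16%, with a range from 6% to 26%.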

Compound 4, a percentage reported as inhibition, in the whole organism at one dose (the size of the read-out at that dose, not a potency): 15.4%
The estimate for compound 4 lay 0.6 percentage points above the measured number; measured number inside the range.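

Putting fluoro in place of chloro on the core of compound 3 gives a number 3.1 percentage points higher from compound 3 to compound 4 (within the scatter) in this assay, and this change carries over from one core to the other with no visible difference: the same change on two cores in this assay, a number 3.6 percentage points higher (within the scatter) from compound 1 to compound 2 and a number 3.1 percentage points higher (within the scatter) from compound 3 to compound 4, 0.5 percentage points apart, within the scatter of two such steps

The other change, 3-nitrophenyl in place of 4-bromophenyl, can now be read a second time, as a number 7.2 percentage points lower from compound 2 to compound 4 (within the scatter), and it also carries over: the same change on two cores in this assay, a number 6.7 percentage points lower (within the scatter) from compound 1 to compound 3 and a number 7.2 percentage points lower (within the scatter) from compound 2 to compound 4, 0.5 percentage points apart, within the scatter of two such steps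

For the compounds shown here, still, each of these steps lies within the scatter, so the agreement shows only that neither change behaves noticeably differently on these cores; it does not show that either step is a real effect, and two cores give no rule for the whole series.

The compounds shown leave open whether an amine or a methoxy group in place of chloro or fluoro would move the inhibition beyond the scatter. They also leave open what a carboxylic acid or a longer chain would do in place of the (4-fluorobenzyl)sulfanyl group.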